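The source may hold more compounds than are shown below. What is called first, only, known or untested is meant among the compounds shown, and "the series" means these compounds.

Measured so far in an assay on HEK293 cells for displacement of a labelled ligand from Neuronal acetylcholine receptor; alpha3/beta4 (Homo sapiens); a higher number here means a weaker inhibitor, a lower number a stronger inhibitor:

- Compound 1, `O=[N+]([O-])c1ccc(Nc2ccc(N3CC4CC(C3)N4)cn2)cc1`: compound 1 gives 25 nM
- Compound 2, `FC(F)(F)c1ccc(Nc2ccc(N3CC4CC(C3)N4)cn2)cc1`: compound 2 gives 0.818 nM
- Compound 3, `Oc1ccc(Nc2ccc(N3CC4CC(C3)N4)cn2)cc1`: compound 3 gives 165 nM

Compound 3 stands highest of these three numbers, which means it is the weakest inhibitor shown. Its nearest neighbour is compound 1, reached by the step of a 6.6-fold higher number from compound 1 to compound 3 (0.82 log units; beyond the scatter); its most distant is compound 2, reached by the step of a 200-fold higher number from compound 2 to compound 3 (2.30 log units; beyond the scatter).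

Compound 4, `Clc1cccc(Nc2ccc(N3CC4CC(C3)N4)cn2)c1`, differs from compound 3 by a single change: 3-chlorophenyl in place of 4-hydroxyphenyl on a nitrogen on an aromatic ring.

Among the measured compounds shown here, two measured steps bear on this change, since both also exchange the hydroxy group on that ring for a group that carries no hydrogen-bond donor or acceptor. Read toward compound 3, the step of a 6.6-fold higher number from compound 1 to compound 3 (0.82 log units; beyond the scatter) was modest and the step of a 200-fold higher number from compound 2 to compound 3 (2.30 log units; beyond the scatter) was large, so moving away from the hydroxy group went in both cases toward a lower number in this assay. Chlorine, however, sits at a different position on the ring than nitro or trifluoromethyl did, and no measured pair tests that arrangement, so the size is uncertain. A clearly lower number than compound 3 is expected, the estimated step being a 21-fold lower number from compound 3 to compound 4 (1.31 log units; beyond the scatter). Compound 4 is therefore estimated at 8 nM, with a likely range from 1.5 nM to 45 nM.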

Compound 4, inhibition constant: 4.8 nM
Compound 4: the middle estimate sits 1.7-fold (0.22 log units) above what was measured; measured number inside the range.
By their numbers in this assay, from the lowest: compound 2; then compound 4; then compound 1; then compound 3.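

The step of a 34-fold lower number from compound 3 to compound 4 (1.54 log units; beyond the scatter) shows that a lower number on leaving the 4-hydroxyphenyl group is not confined to the nitro and trifluoromethyl compounds, since it also appears with a chlorine placed elsewhere on the ring, as in the 3-chlorophenyl group. This single step changes both the substituent and where it sits, so it cannot show how much of the change belongs to each. Nothing available explains the size of this step.

The compounds shown leave open how a 4-chlorophenyl group would compare with the 3-chlorophenyl group, which would separate the two changes. They also leave open whether an amine or a carboxylic acid on this ring would give a number closer to that of compound 3 or that of compound 4.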